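A few compounds are considered here, and "the series" means these few. Any claim that something is new, unique, unknown or untested is made for them only; others in the source may bear on it.

Three compounds of the series have numbers in a functional assay on MCF7 cells (Homo sapiens) for inhibition, read by MTT assay, with a stated time of 48 h; a higher number here means a weaker inhibitor, a lower number a stronger inhibitor. Compound 1 `Cc1cc(C)c2c(c1)CN(c1ccc3c(=O)cc(-c4ccccc4)oc3c1)CO2` gives 61900 nM, compound 3 `O=c1cc(-c2ccccc2)oc2cc(N3COc4c(Cl)cc(Cl)cc4C3)ccc12` gives 44500 nM, and compound 2 `Cc1cccc2c1OCN(c1ccc3oc(-c4ccccc4)cc(=O)c3c1)C2` gives 14300 nM, the lowest of the three; its gaps to compound 3 and to compound 1 both lie beyond the scatter. Within the data shown here, no pair of measured compounds differs in a single place, so no isolated step is available. Compound 4 `O=c1cc(-c2ccccc2)oc2ccc(N3COc4c(Br)cccc4C3)cc12` differs from compound 2 by bromo in place of methyl on an aromatic carbon. Neither compound 1 nor compound 3 isolates this exchange, so its size cannot be read from the set. The expected step is a 1.7-fold higher number from compound 2 to compound 4 (0.24 log units; within the scatter), a modest weakening that may not exceed the scatter. Compound 4 is estimated at 25000 nM, with a range from 8000 nM to 80000 nM.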

Compound 4, half-maximal inhibitory concentration: 19600 nM
Estimate against measurement, compound 4: 1.3-fold (0.11 log units) above; the range from low to high includes it.
By their numbers in this assay, from the lowest: compounds 2 and 4 (each within the scatter of the next); then compounds 3 and 1 (each within the scatter of the next).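

In this assay, bromo in place of methyl on an aromatic carbon, ortho to a fused ring and meta to a fused ring, gives a 1.4-fold higher number from compound 2 to compound 4 (0.14 log units; within the scatter) and so leaves the number within the scatter. Among these compounds, this is the first exchange isolated at one place, and at this position the two groups cannot be told apart. No measurement on hand accounts for this result. Open, on these data alone, is how a hydrogen, an amine, a carboxylic acid or a longer chain would read at this position.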